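A few compounds are considered here, and "the series" means these few. Any claim that something is new, unique, unknown or untested is made for them only; others in the source may bear on it.

Compound 1 `Cc1ccc(S(=O)(=O)N2CC[C@@H](Cl)C[C@@H]2C2CCCCC2)cc1` carries a cyclohexyl group on a saturated ring carbon of its core, and in a functional assay on WiDr cells (Homo sapiens) for antiproliferative activity, read by sulforhodamine B assay, with a stated time of 48 h (a higher number here means a weaker inhibitor of growth, a lower number a stronger inhibitor of growth), compound 1 gives 15000 nM. Compound 2 `Cc1ccc(S(=O)(=O)N2CC[C@@H](Cl)C[C@@H]2c2ccccc2)cc1` differs from it in one place, (phenyl in place of cyclohexyl on a saturated ring carbon), and in this assay compound 2 gives 37000 nM; the step of a 2.5-fold higher number from compound 1 to compound 2 (0.39 log units; beyond the scatter) runs toward weaker growth inhibition. Compound 3 `Cc1ccc(S(=O)(=O)N2CCC(Cl)=CC2C2CCCCC2)cc1` is built on a different core; how that core differs from the core of compound 1 is not broken down here. In this assay compound 3 gives 24000 nM, a number that sits within the usual scatter of both compound 2 and compound 1. Compound 4 `Cc1ccc(S(=O)(=O)N2CCC(Cl)=CC2c2ccccc2)cc1` has not yet been measured. It differs from compound 3 by phenyl in place of cyclohexyl on a saturated ring carbon, the same change as between compound 1 and compound 2, at a place described in identical words. For the measured compounds named here, since the one precedent for this change, a 2.5-fold higher number from compound 1 to compound 2 (0.39 log units; beyond the scatter), gave a higher number, compound 4 is expected to show a step of similar size, a 2.5-fold higher number from compound 3 to compound 4 (0.40 log units; beyond the scatter). The expected value for compound 4 in this assay is 60000 nM, with a likely range from 30000 nM to 120000 nM.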

Compound 4, concentration for 50% growth inhibition: 18000 nM
For compound 4 the middle estimate is 3.3-fold (0.52 log units) above the measured one, and the stated range ends above it.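

In this assay, the change of phenyl in place of cyclohexyl on a saturated ring carbon did not carry over in the same way from one core to the other: the same change on two cores in this assay, a 2.5-fold higher number (0.39 log units; beyond the scatter) from compound 1 to compound 2 and a 1.3-fold lower number (0.12 log units; within the scatter) from compound 3 to compound 4, 3.3-fold (0.52 log units) apart, beyond the scatter of two such steps The new step, a 1.3-fold lower number from compound 3 to compound 4 (0.12 log units; within the scatter), shows no real separation, so the weaker growth inhibition seen with this change on the core of compound 1 does not reappear on the core of compound 3. For the compounds shown here, this shows that, in these four compounds, the effect of the change cannot simply be copied across cores, but with only two pairs it does not show why the cores differ or what the change would do on any further core.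

The compounds shown carry only cyclohexyl or phenyl at this place, so it remains open how an amine, a carboxylic acid or a longer chain there would behave on either core. Going by these compounds, all of these numbers come from this assay, so whether the same picture holds in other cells also remains open.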